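Swapping a methoxyphenyl for a dichlorophenyl: any cost in toxicity?

This account rests on a few compounds, and the source may have more. Where it says the series, first, only, none or still open, it means among the compounds named here.

This series shares one core, carried by compound 1 `Fc1cccc(F)c1Cn1ccc2nc(-c3c(F)cccc3F)nc-2c1`, compound 2 `Fc1cccc(F)c1Cn1cccc2nc(-c3c(F)cccc3F)nc1-2` and compound 3 `COc1cccc(Cn2ccc3nc(-c4ccccc4)nc-3c2)c1`, and the question is how each pendant ring affects the safety read-out of an ADME assay on MDBK cells (Bos taurus) for cytotoxicity; on this read-out higher numbers stand for lower toxicity in this test and lower numbers for higher toxicity in this test. In this assay compound 1 gives only a limit of > 100000 nM. Compound 2 likewise reaches only a limit of > 100000 nM in this assay. Compound 3, the starting point here, also gives only a limit of > 100000 nM in this assay. So compound 3 stands nowhere apart from its two companions: all three sit at the limit of > 100000 nM in this assay, at which 3 of the 3 values shown sit, and no difference among them can be read from the numbers.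

Compound 4 `Clc1ccc(Cn2ccc3nc(-c4ccccc4)nc-3c2)cc1Cl` is not yet measured. It differs from compound 3 by 3,4-dichlorophenyl in place of 3-methoxyphenyl on a saturated chain carbon bound to an aromatic nitrogen, with no change to the shared core.

Going by the values given here, because every value shown is the limit of > 100000 nM in this assay, at which 3 of the 3 values shown sit, there is no measured step to lean on. The change in this assay from compound 3 to compound 4 is expected to be a number no higher from compound 3 to compound 4 (the limit leaves the size open), that is, none beyond the usual scatter. Compound 4 is therefore estimated at 100000 nM in this assay, within a range from 40000 nM to 300000 nM, and most likely the test will again report only a limit.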

Compound 4, half-maximal cytotoxic concentration: 71000 nM
For compound 4 the middle estimate is 1.4-fold (0.15 log units) above the measured one; measured number inside the range.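

In this assay, compound 4 is the only compound shown that gives a measured number, 71000 nM, rather than a limit, so this position on a saturated chain carbon bound to an aromatic nitrogen can carry a group that brings the read-out within the range of the test. Replacing 3-methoxyphenyl with 3,4-dichlorophenyl there gives an at least 1.4-fold lower number from compound 3 to compound 4 (0.14 log units; that floor lies within the scatter), so the data neither establish a real cost in toxicity nor rule one out. The true size of the step stays unknown because the starting value is not a number: the limit of > 100000 nM in this assay, at which 3 of the 4 values shown sit.

The compounds shown do not separate the effect of adding the two chlorine atoms from that of losing the methoxy group, and a ring carrying only one chlorine could begin to tell these apart. Going by these compounds, it also remains open how a benzyl group bearing an amine or a carboxylic acid at this position would read in this assay, and whether any such ring would give a number or another limit.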